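The compounds below may be only part of what the source reports. "The series", "measured", "known", "first", "only" and "open" are said of these compounds alone.

Compounds measured so far:
compound 1, `COc1ccc(C(=O)Nc2ccc3nc(NC(=O)C4CCCCC4)sc3c2)cc1` — 4.9 ug/mL
compound 2, `CCC(C)(C)C(=O)Nc1ccc2nc(NC(=O)C3CCCCC3)sc2c1` — 1 ug/mL
compound 3, `CC(=O)Nc1nc2ccc(NC(=O)c3c(Cl)cccc3Cl)cc2s1` — 0.6 ug/mL

These three share a core and were tested in a functional assay on WI-38 VA13 cells (Homo sapiens) for cytotoxicity; on this read-out higher numbers stand for an effect only at larger amounts of compound and lower numbers for an effect already at smaller amounts. Compound 3 gives the lowest number of the three; its gap to compound 2 is within the scatter, while its gap to compound 1 is beyond it. Compound 4 is `COc1ccc(Nc2nc3ccc(NC(=O)c4c(Cl)cccc4Cl)cc3s2)cc1`, not yet measured. It differs from compound 3 in one place: 4-methoxyphenyl in place of acetyl on a nitrogen on an aromatic ring.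

For the measured compounds named here, only one measured step bears on this change. Going a 4.9-fold lower number from compound 1 to compound 2 (0.69 log units; beyond the scatter), the 4-methoxyphenyl group left a carbonyl carbon in favour of a branched alkyl group and the number fell modestly. In compound 4 a 4-methoxyphenyl group enters, though on a nitrogen on an aromatic ring rather than on a carbonyl carbon, and in place of acetyl rather than a branched alkyl. Read in reverse, that step suggests a modest rise when the aryl group is present, but the different place of the change and the lack of any second example keep the expectation loose. A rise of about a 2.5-fold higher number from compound 3 to compound 4 (0.40 log units; beyond the scatter) is expected, possibly within the scatter, and compound 4 is estimated at 1.5 ug/mL, between 0.5 ug/mL and 5 ug/mL.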

Compound 4, half-maximal effective concentration: 0.87 ug/mL
Beside the measured number, compound 4's estimate is 1.7-fold (0.24 log units) above it; measured number inside the range.
By their numbers in this assay, from the lowest: compounds 3, 4 and 2 (each within the scatter of the next); then compound 1.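

In this assay, putting 4-methoxyphenyl in place of acetyl on this nitrogen on an aromatic ring gives a 1.5-fold higher number from compound 3 to compound 4 (0.16 log units; within the scatter). This step stays within the usual scatter, so a group of 8 heavy atoms with a ring can stand where a group of 3 heavy atoms with no ring stood, with no readable shift in the number, and the carbonyl of the acetyl is not needed to keep the number in this range. For the compounds shown here, the only earlier step, a 4.9-fold lower number from compound 1 to compound 2 (0.69 log units; beyond the scatter), lay beyond the scatter but concerned a carbonyl carbon, a different place, so this is the first view of what a change on this nitrogen does, and nothing measured here explains why it leaves the number in place.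

Going by these compounds, this rests on a single pair, so it remains open whether a plain phenyl, a phenyl carrying a carboxylic acid, a primary amine or a longer alkyl chain on this nitrogen would also stay within the scatter of compound 3. On these data alone, it is equally open whether 4-methoxyphenyl on this nitrogen would give the same picture with 1,1-dimethylpropyl on the carbonyl carbon.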